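The source may hold more compounds than are shown below. What is called first, only, known or untested is meant among the compounds shown, and "the series" means these compounds.

Measured compounds:
- compound 1, `COc1cc(N2C(N)=C(C#N)C(c3ccc([N+](=O)[O-])cc3)C3=C2CC(C)(C)CC3=O)cc(OC)c1OC`: 80%
- compound 2, `COc1cc(N2C(N)=C(C#N)C(/C=C/c3ccccc3)C3=C2CC(C)(C)CC3=O)cc(OC)c1OC`: 40%
- compound 3, `COc1cc(N2C(N)=C(C#N)C(c3ccc(OC)c4ccccc34)C3=C2CC(C)(C)CC3=O)cc(OC)c1OC`: 40%

In a functional assay on Ehrlich cells (Mus musculus) for cytotoxicity, tested at 100 ug/mL (on this read-out lower numbers stand for a weaker effect and higher numbers for a stronger effect at the one concentration tested), compound 1 gives 80%. Compound 2 gives 40% and compound 3 gives 40% in this assay, so compound 3 stands level with compound 2 at the digits shown, the two together being the lowest of the three numbers, while compound 1 sits above both (a number 40 percentage points lower from compound 1 to compound 3 (beyond the scatter), a number 40 percentage points lower from compound 1 to compound 2 (beyond the scatter)). The step between compound 2 and compound 3 is no change at the digits printed from compound 2 to compound 3 (within the scatter).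

Compound 4, `COc1cc(N2C(N)=C(C#N)C(c3ccccc3)C3=C2CC(C)(C)CC3=O)cc(OC)c1OC`, has not yet been measured in this assay. It differs from compound 3 in one place: phenyl in place of 4-methoxynaphthalen-1-yl on a saturated ring carbon. Within the data shown here, no measured step introduces phenyl, so none bears directly on this change; the two steps from compound 1 show that exchanging the group on this saturated ring carbon can shift the number by a large amount, whereas the exchange between compound 2 and compound 3 left it unchanged. The expected step is therefore no change at the digits printed from compound 3 to compound 4 (within the scatter), with wide uncertainty. Compound 4 is estimated at 40%, within 15% to 70%.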

Compound 4, a percentage reported as activity, at one concentration (the size of the read-out at that concentration, not a potency): 10%
The estimate for compound 4 lay 30 percentage points above the measured number; measured number outside the range, below it.
By their numbers in this assay, from the lowest: compound 4; then compounds 2 and 3 (each within the scatter of the next); then compound 1.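

In this assay, phenyl does not behave like the other groups on this saturated ring carbon: the exchange gives a number 30 percentage points lower from compound 3 to compound 4 (beyond the scatter) and a number 30 percentage points lower from compound 2 to compound 4 (beyond the scatter), so the match between compound 2 and compound 3 does not extend to every group here. Hydrogen in place of nitro gives a number 70 percentage points lower from compound 1 to compound 4 (beyond the scatter), which ties the high number of compound 1 to the nitro group on that phenyl ring rather than to the phenyl ring alone. Nothing given here accounts for these differences.

On these data alone, it remains open whether another group on the phenyl ring, such as an amine, a chlorine or a carboxylic acid, would also raise the number. The contribution of the 3,4,5-trimethoxyphenyl group on the ring nitrogen also remains open, as every compound shown carries it.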